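The compounds below may be only part of what the source reports. "The series", "measured", "known", "first", "only" and "open" are said of these compounds alone.

Compound 1 `COCCOC(=O)c1cc(N)c(Nc2ccc(C#N)cc2)cc1Oc1c(C)cc(/C=C/C#N)cc1C` gives 0.317 h in an ADME assay on microsomes from liver (Homo sapiens) for metabolic stability, read by LC-MS, using NADPH, with a stated time of 45 min, tested at 1 uM (a higher number here means that the compound lasts longer, a lower number that the compound disappears faster), the lowest of the three numbers recorded. Compound 2 `Cc1cc(/C=C/C#N)cc(C)c1Oc1cc(Nc2ccc(C#N)cc2)c(N)cc1C(=O)NN` gives 0.6 h and compound 3 `Cc1cc(/C=C/C#N)cc(C)c1Oc1cc(Nc2ccc(C#N)cc2)c(N)cc1C(N)=O` gives 1.5 h. The step of a 1.9-fold higher number from compound 1 to compound 2 (0.28 log units; within the scatter) stays within the scatter, whereas a 4.7-fold higher number from compound 1 to compound 3 (0.68 log units; beyond the scatter) goes beyond it, as does a 2.5-fold higher number from compound 2 to compound 3 (0.40 log units; beyond the scatter). Compound 4 `Cc1cc(/C=C/C#N)cc(C)c1Oc1cc(Nc2ccc(C#N)cc2)c(N)cc1C(=O)NCCC(F)F` differs from compound 1 by (3,3-difluoropropyl)amino in place of 2-methoxyethoxy on a carbonyl carbon. Both measured steps from compound 1 replaced the same 2-methoxyethoxy group on the carbonyl carbon with an amino-type group; only compound 3 moved beyond the scatter, and in the upward direction. A modest rise is therefore expected here as well, as a 3.2-fold higher number from compound 1 to compound 4 (0.50 log units; beyond the scatter). The value expected for compound 4 in this assay is 1 h, within a range from 0.4 h to 2.5 h.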

Compound 4, half-life: 0.233 h
Compound 4: the middle estimate sits 4.3-fold (0.63 log units) above what was measured; the measured number lies below the stated range.
By their numbers in this assay, from the lowest: compounds 4, 1 and 2 (each within the scatter of the next, the first and the last beyond it); then compound 3.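

At this carbonyl carbon, an amide alone does not bring the rise seen with compound 3: in this assay, (3,3-difluoropropyl)amino gives a 1.4-fold lower number from compound 1 to compound 4 (0.13 log units; within the scatter). What separates the amides is the group on the amide-type nitrogen, with a 6.4-fold lower number from compound 3 to compound 4 (0.81 log units; beyond the scatter) and a 2.6-fold lower number from compound 2 to compound 4 (0.41 log units; beyond the scatter). No measurement available here explains this difference. From the compounds shown here alone, it remains open whether a methyl or a plain propyl group on that nitrogen would stay nearer compound 3 or compound 4, and so whether the chain or its two fluorines matter.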